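A few compounds are considered here, and "the series" means these few. Any claim that something is new, unique, unknown or untested is made for them only; others in the source may bear on it.

Measured compounds:
compound 1, `Cc1nc2c(OCc3ccccc3)cccn2c1C#N`, 25%
compound 2, `[C-]#[N+]Cc1c(C)nc2c(OCc3ccccc3)cccn12`, 96%
compound 3, `CSCc1c(C)nc2c(OCc3ccccc3)cccn12`, 29%

These three numbers come from a functional assay on the whole organism with Rattus norvegicus as the target, with a stated time of 4 h, at a dose of 40 mg/kg by the intraperitoneal route; a higher number here means more inhibition at the dose given (going by the name of the read-out), a lower number less inhibition. Compound 3 stands second highest of the three, close to compound 1 and far from compound 2: the pair of compound 1 and compound 3 differs by a number 4 percentage points higher from compound 1 to compound 3 (within the scatter), which is within the scatter, while the step of a number 67 percentage points lower from compound 2 to compound 3 (beyond the scatter) is a large fall, well beyond the scatter.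

Compound 4, `Cc1nc2c(OCc3ccccc3)cccn2c1CC(=O)O`, has not yet been measured. It differs from compound 3 by carboxy in place of methylsulfanyl on a saturated chain carbon bound to an aromatic carbon. Going by the values given here, the only measured step at this same place is the one from compound 2 to compound 3, where an exchange on the saturated chain carbon gave a large fall, a number 67 percentage points lower from compound 2 to compound 3 (beyond the scatter). That step shows the place itself can carry a big swing, but the group that enters in compound 4 resembles neither of the groups compared there, so the direction of the new step cannot be read from it. The exchange at the aromatic carbon from compound 1 to compound 3, a number 4 percentage points higher from compound 1 to compound 3 (within the scatter), stayed within the scatter and is a different kind of change.

Among the compounds with values here, with no closer precedent, the expectation for compound 4 is a step of about a number 1 percentage points higher from compound 3 to compound 4 (within the scatter), that is, no change beyond the scatter, with wide uncertainty. Compound 4 is therefore estimated at 30%, in the range 8% to 62%.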

Compound 4, a percentage reported as inhibition, in the whole organism at one dose (the size of the read-out at that dose, not a potency): 12%
Compound 4: middle estimate off by 18 percentage points, on the high side; measured number inside the range.
By their numbers in this assay, from the lowest: compound 4; then compounds 1 and 3 (each within the scatter of the next); then compound 2.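

At this place, carboxy in place of methylsulfanyl moves the number further down (a number 17 percentage points lower from compound 3 to compound 4 (beyond the scatter)), a modest step, so the fall seen with methylsulfanyl was not the floor for this saturated chain carbon, and against the group of compound 2 the change is a large fall (a number 84 percentage points lower from compound 2 to compound 4 (beyond the scatter)) that leaves compound 4 the lowest of the four in this assay. Seen as an exchange on the aromatic carbon, carboxymethyl in place of cyano also gives a modest fall (a number 13 percentage points lower from compound 1 to compound 4 (beyond the scatter)), whereas (methylsulfanyl)methyl in place of cyano stayed within the scatter (a number 4 percentage points higher from compound 1 to compound 3 (within the scatter)), so the two chains on that carbon do not behave alike. The data at hand offer no measurement that explains these differences.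

Still open, on these data alone, is whether an amine or a methyl ester on the same saturated chain carbon would reach the high number of compound 2 or stay down with compounds 1, 3 and 4. Also open, as far as these compounds go, is whether a longer chain ending in a carboxylic acid would differ from carboxymethyl, and since each number comes from a single dose, none of them gives a potency.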